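From methyl to benzyloxy on the shared core

The source may hold more compounds than are shown below. What is called first, only, known or untested is meant among the compounds shown, and "the series" means these compounds.

In a functional assay on HT-29 cells (Homo sapiens) for antiproliferative activity, read by MTT assay, with a stated time of 48 h (on this read-out lower numbers stand for stronger inhibition of growth and higher numbers for weaker inhibition of growth), compound 1 `Fc1ccc(C2=NN(C(=S)Nc3ccccc3)C(c3ccc4c(c3)OCCO4)C2)cc1` gives 37600 nM and compound 2 `Cc1ccc(C2=NN(C(=S)Nc3ccccc3)C(c3ccc4c(c3)OCCO4)C2)cc1` gives 19500 nM. Within the data shown here, these two values lie within the scatter of each other, so compound 2 holds no clear rank on the numbers so far. Compound 3 `S=C(Nc1ccccc1)N1N=C(c2ccc(OCc3ccccc3)cc2)CC1c1ccc2c(c1)OCCO2` has not yet been measured. It differs from compound 2 in one place: benzyloxy in place of methyl on an aromatic carbon. Among the measured compounds shown here, only one measured step bears on this change, a 1.9-fold lower number from compound 1 to compound 2 (0.29 log units; within the scatter), with methyl in place of fluoro on an aromatic carbon. For the measured compounds named here, no measured compound carries benzyloxy, so that small step offers weak guidance, and no shift beyond the scatter is expected in this assay. The expected change is a 1.3-fold lower number from compound 2 to compound 3 (0.11 log units; within the scatter). For compound 3 the estimated value is 15000 nM, with an expected range from 4000 nM to 50000 nM.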

Compound 3, concentration for 50% growth inhibition: 860 nM
Compound 3: middle estimate off by 17-fold (1.24 log units), on the high side; measured number below the stated range.
By their numbers in this assay, from the lowest: compound 3; then compounds 2 and 1 (each within the scatter of the next).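

In this assay, the aromatic carbon para to a large group proves far from indifferent to what it carries, although fluoro and methyl there could not be told apart. Benzyloxy gives a 23-fold lower number from compound 2 to compound 3 (1.36 log units; beyond the scatter), and against fluoro it gives a 44-fold lower number from compound 1 to compound 3 (1.64 log units; beyond the scatter), so a group of 8 heavy atoms, with one oxygen and a six-membered aromatic ring of carbon only, is not merely accepted at this place but goes with much stronger inhibition of growth. No measurement at hand explains this step.

On these data alone, whether the step rests on the oxygen or on the added ring remains open, and a methoxy group or a phenyl ring at the same place would separate the two. Also open, as far as these compounds go, is how a longer chain ending in a phenyl ring, or a benzyloxy group with a chloro substituent, would compare.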